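A few compounds are considered here, and "the series" means these few. Any claim that something is new, unique, unknown or untested is made for them only; others in the source may bear on it.

Measured compounds and their values:

Compound 1, `COc1c(OC)c(OC(=O)C(C)(C)C)c2ccccc2c1OC(=O)C(C)(C)C`, gives 5.69 in a physicochemical assay for lipophilicity; on this read-out higher numbers stand for higher lipophilicity and lower numbers for lower lipophilicity.
Compound 2, `COc1c(OC)c(OC(C)=O)c2cc(C)ccc2c1OC(C)=O`, gives 2.86 in this assay.
Compound 3, `COc1c(OC)c(OC(=O)C(C)(C)C)c2cc(C)ccc2c1OC(=O)C(C)(C)C`, gives 6.1 in this assay.

Compound 1 and compound 3 differ by one change, (methyl in place of hydrogen on an aromatic carbon). That change raised the number: a number 0.41 log units higher from compound 1 to compound 3 (beyond the scatter). Compound 2 shares the two methoxy groups and the two ester groups on its core with compound 1, but the difference between the two cores is not broken down here; what the values show is that compound 2 stands far below compound 1 and compound 3 in this assay, beyond the scatter in both cases.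

Compound 4, `COc1c(OC)c(OC(C)=O)c2cc(C)c(C)cc2c1OC(C)=O`, has not yet been measured. It differs from compound 2 by methyl in place of hydrogen on an aromatic carbon. Among the measured compounds shown here, this is the same kind of change as the one from compound 1 to compound 3, though not the same: in compound 4 the new methyl group sits ortho to a methyl group that is already there, whereas in compound 3 no such neighbour is described. Only one measured example of this kind of change exists among these compounds, so the expectation rests on that single step. Because the step of a number 0.41 log units higher from compound 1 to compound 3 (beyond the scatter) was a modest rise, a rise of similar size is expected from compound 2 to compound 4, that is, about a number 0.41 log units higher from compound 2 to compound 4 (beyond the scatter). Compound 4 is therefore estimated to give around 3.27 in this assay, most likely between 2.95 and 3.65.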

Compound 4, partition coefficient: 3.14
Compound 4: middle estimate off by 0.13 log units, on the high side; the measured number falls inside the stated range.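

In this assay, putting methyl in place of hydrogen on an aromatic carbon of the core of compound 2 gives a number 0.28 log units higher from compound 2 to compound 4 (within the scatter), which cannot be told apart from the ordinary spread of repeated measurements, whereas the same kind of change on the core of compound 1 gave a number 0.41 log units higher from compound 1 to compound 3 (beyond the scatter). So a step that stood clear of the scatter on one core did not do so on the other, but this does not show that the methyl group has no effect on the core of compound 2, or that the two cores truly respond differently: there is only one pair for each core, and the new methyl group in compound 4 sits ortho to a methyl group, so the two changes are not identical. Nothing available here explains the difference between these two readings.

The compounds shown leave open how the number would respond to an amine, a carboxylic acid or a longer chain such as propyl on this aromatic carbon. They also leave open what a second methyl group, ortho to the first, would do on the core of compound 3.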